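The source may hold more compounds than are shown below. What is called first, only, known or untested is meant among the compounds shown, and "the series" means these compounds.

Measured compounds in a functional assay (aorta) for inhibition, with Rattus norvegicus as the target; a lower number here means a stronger inhibitor, a higher number a weaker inhibitor:
compound 1 `CCC(C)Nc1nc(O)c2cc(Cl)ccc2n1` gives 13800 nM
compound 2 `Oc1nc(NCC2CCCCC2)nc2ccc(Cl)cc12` gives 2200 nM
compound 3 `CCC(C)Nc1nc(O)c2cc(I)ccc2n1` gives 8900 nM

Compound 2 has the lowest of the three numbers; its nearest neighbour is compound 3, then compound 1, both beyond the scatter. The difference between the core of compound 1 and the core of compound 2 is not broken down here.

One change is seen on a measured pair: iodo in place of chloro on an aromatic carbon. It gave a 1.6-fold lower number from compound 1 to compound 3 (0.19 log units; within the scatter).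

The unmeasured compound 4 `Oc1nc(NCC2CCCCC2)nc2ccc(I)cc12` carries the same change on the core of compound 2: iodo in place of chloro on an aromatic carbon. The place lines match word for word, so this is taken as the same change. In this assay the step from compound 2 is expected to be about as small as the earlier one, a 1.6-fold lower number from compound 2 to compound 4 (0.20 log units; within the scatter), resting on compound 1 to compound 3 giving a 1.6-fold lower number from compound 1 to compound 3 (0.19 log units; within the scatter). Compound 4 is therefore estimated at 1400 nM, likely between 600 nM and 3500 nM.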

Compound 4, half-maximal inhibitory concentration: 3900 nM
The estimate for compound 4 lay 2.8-fold (0.44 log units) below the measured number, and the stated range ends below it.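

In this assay, iodo in place of chloro on an aromatic carbon gives a 1.8-fold higher number from compound 2 to compound 4 (0.25 log units; within the scatter) on the core of compound 2. Each step is within the scatter on its own, yet the two differ when set side by side: the same change on two cores in this assay, a 1.6-fold lower number (0.19 log units; within the scatter) from compound 1 to compound 3 and a 1.8-fold higher number (0.25 log units; within the scatter) from compound 2 to compound 4, 2.7-fold (0.44 log units) apart, beyond the scatter of two such steps. The change therefore does not carry over as a fixed step between these two cores, but with one pair per core, this does not show what sets the gap or how the change would run on a third core.

Still open, going by these compounds, is how fluoro, methoxy or a nitrile would fare at the same aromatic carbon. Also open, on these data alone, is whether a longer straight chain in place of the side chain of compound 2 would alter the outcome of this change.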